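This account rests on a few compounds, and the source may have more. Where it says the series, first, only, none or still open, it means among the compounds named here.

Working notes on the series in a functional assay on SK-BR-3 cells (Homo sapiens) for antiproliferative activity, read by MTT assay, with a stated time of 72 h; a lower number here means a stronger inhibitor, a higher number a weaker inhibitor.

Among the measured compounds shown here, compound 1 `C/C=C1/[C@H](O[C@@H]2O[C@H](CO)[C@@H](O)[C@H](O)[C@H]2O)OC=C(C(=O)OC)[C@H]1CC(=O)OCCc1ccc(O)c(O)c1` is the only member of the set with a numeric reading: in this assay compound 1 gives 160000 nM. Compound 2 `C/C=C1/[C@H](O[C@@H]2O[C@H](COC(C)=O)[C@@H](OC(C)=O)[C@H](OC(C)=O)[C@H]2OC(C)=O)OC=C(C(=O)O)[C@H]1CC(=O)O` reaches only a limit of the assay, > 20000 nM. Compound 3 `C/C=C1/[C@H](O[C@@H]2O[C@H](COC(C)=O)[C@@H](OC(C)=O)[C@H](OC(C)=O)[C@H]2OC(C)=O)OC=C(C(=O)OC)[C@H]1CC(=O)OCCC1CCCCC1` likewise stops at a limit, > 15000 nM. For the measured compounds named here, with one number and two limits, no step between measured compounds can be sized here.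

Compound 4 `C/C=C1/[C@H](O[C@@H]2O[C@H](CO)[C@@H](O)[C@H](O)[C@H]2O)OC=C(C(=O)OC)[C@H]1CC(=O)OCc1ccc(OC)c(OC)c1` has not been run. It departs from compound 1 as 3,4-dimethoxyphenyl in place of 3,4-dihydroxybenzyl on a saturated chain carbon bound to an oxygen next to a carbonyl group — put one bond further out, 2-(3,4-dihydroxyphenyl)ethyl gives way to 3,4-dimethoxybenzyl. Going by the values given here, no measured step guides this move, so the step of a 1.2-fold lower number from compound 1 to compound 4 (0.09 log units; within the scatter) is expected to stay near the scatter, with no clear direction. Compound 4 is therefore estimated at 130000 nM, spanning 40000 nM to 400000 nM.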

Compound 4, half-maximal inhibitory concentration: > 15000 nM
Compound 4: only a limit was reported; the forecaster's own chance of this, stated with the estimate: 35%; the middle value is on the limit's open side.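

For compound 4 the reading of > 15000 nM is a limit of the assay, and the step from compound 1 to compound 4 cannot be read. On these data alone, whether 3,4-dimethoxybenzyl in place of 2-(3,4-dihydroxyphenyl)ethyl raises or lowers the number stays open.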